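The compounds below may be only part of what the source reports. "The series", "measured", "known", "first", "only" and "open" are said of these compounds alone.

Measured compounds in a functional assay on K562 cells (Homo sapiens) for cytotoxicity, read by CCK-8 assay, with a stated time of 72 h; a lower number here means a stronger inhibitor, a higher number a weaker inhibitor:
compound 1, `C=CCn1c(=O)/c(=C\c2ccccc2OC)[nH]c(=O)/c1=C\c1ccccc1OC`, gives 7400 nM
compound 2, `C=CCn1c(=O)/c(=C\c2ccccc2C(F)(F)F)[nH]c(=O)/c1=C\c1ccccc1OC`, gives 2700 nM

Of these two numbers, compound 2 holds the lower one; the step from compound 1 was a 2.7-fold lower number from compound 1 to compound 2 (0.44 log units; beyond the scatter). Compound 3, `C=CCn1c(=O)/c(=C\c2cc(F)ccc2C)[nH]c(=O)/c1=C\c1ccccc1OC`, differs from compound 2 by 5-fluoro-2-methylphenyl in place of 2-(trifluoromethyl)phenyl on a double-bonded chain carbon bound to an aromatic carbon. For the measured compounds named here, no measured pair shows this exchange itself; the only step touching the same place is the modest one from compound 1 to compound 2, so no large step is expected in this assay. The expected step from compound 2 to compound 3 is a 1.5-fold higher number from compound 2 to compound 3 (0.17 log units; within the scatter), a small move toward a higher number. Compound 3 is estimated at 4000 nM, within 1500 nM to 11000 nM.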

Compound 3, half-maximal inhibitory concentration: 1800 nM
The estimate for compound 3 lay 2.2-fold (0.35 log units) above the measured number; low and high end bracket the measured number.
By their numbers in this assay, from the lowest: compounds 3 and 2 (each within the scatter of the next); then compound 1.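

In this assay, putting 5-fluoro-2-methylphenyl in place of 2-(trifluoromethyl)phenyl on this double-bonded chain carbon gives a 1.5-fold lower number from compound 2 to compound 3 (0.18 log units; within the scatter), so these two groups cannot be told apart here. Set against the 2-methoxyphenyl of compound 1, the same exchange gives a 4.1-fold lower number from compound 1 to compound 3 (0.61 log units; beyond the scatter), so two different groups at this position now stand apart from 2-methoxyphenyl in the same direction. Nothing available explains these numbers. The compounds shown leave open whether the fluoro or the methyl of the entering group carries the step from compound 1. They also leave open how a phenyl group bearing an amine or a carboxylic acid would read at this position.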